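The source may hold more compounds than are shown below. What is called first, only, known or untested is meant among the compounds shown, and "the series" means these compounds.

Measured compounds:
compound 1 `CCOC(=O)C1=Cc2ccccc2OC1(OCc1cn(CC(=O)Nc2ccc(C)cc2)nn1)C(F)(F)F` — 67400 nM
compound 2 `CCOC(=O)C1=Cc2ccccc2OC1(OCc1cc(-c2ccc(Br)cc2)no1)C(F)(F)F` — 52300 nM
compound 3 `COc1ccc(-c2cc(COC3(C(F)(F)F)Oc4ccccc4C=C3C(=O)O)on2)cc1` — > 150000 nM, a limit of the assay

All three were tested in a functional assay on HeLa cells (Homo sapiens) for inhibition, read by MTT assay, with a stated time of 24 h; on this read-out lower numbers stand for stronger inhibition and higher numbers for weaker inhibition. In this assay compound 1 gives 67400 nM, the higher of the two numbers obtained. Compound 2 gives 52300 nM, which lies within the usual scatter of the value for compound 1, so no order between the two can be claimed. For compound 3 the assay reports only a limit, > 150000 nM, and not a number; (the limit of > 150000 nM in this assay, at which 1 of the 3 values shown sits).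

Compound 4 `CCOC(=O)C1=Cc2ccccc2OC1(OCc1cn(-c2ccc(C)cc2)nn1)C(F)(F)F` has not yet been measured. It differs from compound 1 in one place: 4-methylphenyl in place of ((4-methylphenyl)carbamoyl)methyl on an aromatic nitrogen. Going by the values given here, no step between two measured compounds is available to size this change, so the expectation rests on compound 1 alone. The step of a 1.1-fold lower number from compound 1 to compound 4 (0.05 log units; within the scatter) is expected to be small, not beyond the scatter, in either direction. Compound 4 is therefore expected to give about 60000 nM in this assay, with a range from 20000 nM to 150000 nM.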

Compound 4, half-maximal inhibitory concentration: 25100 nM
Estimate against measurement, compound 4: 2.4-fold (0.38 log units) above; measured number inside the range.
By their numbers in this assay, from the lowest: compound 4; then compounds 2 and 1 (each within the scatter of the next). At a limit, above all of these: compound 3.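

In this assay, going by these compounds alone, the change on the aromatic nitrogen gives the first measured step at this position: a 2.7-fold lower number from compound 1 to compound 4 (0.43 log units; beyond the scatter). The number at this position therefore depends on the group it carries, and the full ((4-methylphenyl)carbamoyl)methyl group, with its amide hydrogen and carbonyl, is not needed to keep the activity, since the shorter 4-methylphenyl gives the lower number. Nothing measured here explains why the number falls with this change.

This single pair cannot show whether the gain comes from losing the amide or from the shorter distance to the aromatic ring, and a benzyl group on the same nitrogen would separate the two. It also leaves open how a ring bearing an amine, or a plain alkyl chain with no aromatic ring, would fare at this position.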